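A few compounds are considered here, and "the series" means these few. Any claim that something is new, unique, unknown or untested is made for them only; others in the source may bear on it.

Measured so far:
compound 1, `O=C(CN1CCN(c2ccccc2F)CC1)Nc1nc2ccccc2[nH]1`: 37.4%
compound 2, `O=C(CN1CCN(c2ccccn2)CC1)Nc1nc2ccccc2[nH]1`: 50%

The two compounds share one core and differ only in the aromatic group on an amine nitrogen in a ring. In a functional assay, read by spectrophotometry, with a stated time of 30 min, tested at 50 ug/mL (on this read-out lower numbers stand for a weaker effect and higher numbers for a stronger effect at the one concentration tested), compound 1 gives 37.4%, while in this assay compound 2 gives 50%, the higher of the two numbers. Within the data shown here, the only step between them is a number 12.6 percentage points higher from compound 1 to compound 2 (beyond the scatter), a change in the same aromatic group.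

Compound 3, `O=C(CN1CCN(c2ccc([N+](=O)[O-])cc2)CC1)Nc1nc2ccccc2[nH]1`, is not yet measured. It differs from compound 2 in one place: 4-nitrophenyl in place of pyridin-2-yl on an amine nitrogen in a ring. Among the measured compounds shown here, the one measured step bears on it only loosely: it shows that swapping the aromatic group on this nitrogen can shift the read-out by a modest amount, but nothing is known about the 4-nitrophenyl group itself, so the direction cannot be told. The expected step is therefore small, a number 5 percentage points lower from compound 2 to compound 3 (within the scatter), with a wide range on either side. Compound 3 is expected to give about 45% in this assay, estimated between 28% and 62%.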

Compound 3, a percentage reported as activity, at one concentration (the size of the read-out at that concentration, not a potency): 44.8%
For compound 3 the middle estimate is 0.2 percentage points above the measured one; measured number inside the range.
By their numbers in this assay, from the lowest: compounds 1, 3 and 2 (each within the scatter of the next, the first and the last beyond it).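

In this assay the 4-nitrophenyl group on this amine nitrogen gives a number 5.2 percentage points lower from compound 2 to compound 3 (within the scatter) when it replaces pyridin-2-yl and a number 7.4 percentage points higher from compound 1 to compound 3 (within the scatter) when it replaces 2-fluorophenyl, so the read-out of compound 3 cannot be told apart from that of either earlier compound. The first pair alone left room for the idea that the ring nitrogen of pyridin-2-yl was needed to reach the number of compound 2, but compound 3, with a ring of carbon only, stays within the scatter of compound 2, so that ring nitrogen is not required; compound 1 also has a ring of carbon only, and its step to compound 2 is the one beyond the scatter. No measured evidence is available to explain why these groups read as they do.

On these data alone, it remains open how the plain phenyl group would compare, which would show what the nitro or fluoro group adds to the ring. As far as these compounds go, all three groups here are six-membered aromatic rings, so the effect of a non-aromatic group on this nitrogen, such as cyclohexyl or a longer alkyl chain, also remains open.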